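A few compounds are considered here, and "the series" means these few. Any claim that something is new, unique, unknown or untested is made for them only; others in the source may bear on it.

Going by the values given here, in a functional assay on OVCAR-5 cells (Homo sapiens) for inhibition, read by CCK-8 assay, with a stated time of 72 h, tested at 10 uM (on this read-out higher numbers stand for more inhibition of growth at the one concentration tested and lower numbers for less inhibition of growth), compound 1 (`CN(C)C(=O)c1cc2cnc(Nc3ccc(NC(=O)C4(C(=O)Nc5ccc(Cl)cc5)CC4)cc3)nc2n1C1CCCC1`) gives 85.3% and compound 2 (`CN(C)C(=O)c1cc2cnc(Nc3ccc(NC(=O)C4(C(=O)Nc5ccc(Cl)c(C(F)(F)F)c5)CC4)cc3)nc2n1C1CCCC1`) gives 48% as the lower of the two numbers measured so far. Among the compounds with values here, compound 3 (`Cc1ccc(NC(=O)C2(C(=O)Nc3ccc(Nc4ncc5cc(C(=O)N(C)C)n(C6CCCC6)c5n4)cc3)CC2)cc1`) has no measurement yet. It differs from compound 2 by 4-methylphenyl in place of 4-chloro-3-(trifluoromethyl)phenyl on an amide-type nitrogen. Within the data shown here, compound 3 carries no trifluoromethyl, and the one measured step that bears on this is a number 37.3 percentage points lower from compound 1 to compound 2 (beyond the scatter) with trifluoromethyl in place of hydrogen on an aromatic carbon, so a large upward step is expected in this assay on this change. Among the measured compounds shown here, that expected step is set a little smaller than the measured one, as no measured step covers the methyl group itself. The estimated move is a number 27 percentage points higher from compound 2 to compound 3 (beyond the scatter) on this reasoning. For compound 3 the estimated value is 75% within a range of 55% to 90% on this read-out.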

Compound 3, percent growth inhibition at one concentration: 80.6%
The estimate for compound 3 lay 5.6 percentage points below the measured number; low and high end bracket the measured number.
By their numbers in this assay, from the lowest: compound 2; then compounds 3 and 1 (each within the scatter of the next).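

In this assay, 4-methylphenyl in place of 4-chloro-3-(trifluoromethyl)phenyl on the amide-type nitrogen gives a number 32.6 percentage points higher from compound 2 to compound 3 (beyond the scatter), so this position can carry a group without chlorine or fluorine and still give a high number. Methyl in place of chloro on an aromatic carbon gives a number 4.7 percentage points lower from compound 1 to compound 3 (within the scatter), so chloro and methyl cannot be told apart here, and among these three compounds only compound 2, the one bearing trifluoromethyl, stands apart. No measurement given here points to a cause for these numbers.

Still open, going by these compounds, is how an aromatic ring carrying a methoxy group, an amine or a carboxylic acid would fare on this amide-type nitrogen. Also open, on these data alone, is whether trifluoromethyl lowers the number on a ring without chloro.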